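Swapping a fluorinated phenyl for a methylpyridine on the amide

A few compounds are considered here, and "the series" means these few. Any claim that something is new, unique, unknown or untested is made for them only; others in the source may bear on it.

Measured so far:
- compound 1, `Cc1ccccc1N(C)C(=O)c1ccc(-c2cccc(OS(N)(=O)=O)c2)o1`, 690 nM
- compound 2, `Cc1ccccc1N(C)C(=O)c1ccc(-c2ccc(OS(N)(=O)=O)cc2Cl)o1`, 27 nM
- compound 3, `Cc1cccc(F)c1N(C)C(=O)c1ccc(-c2ccc(OS(N)(=O)=O)cc2)o1`, 150 nM

All three share the same core and differ only in the ring on the amide nitrogen or on the sulfamate-bearing ring. In an assay on T47D cells for inhibition of Steryl-sulfatase (Homo sapiens), read by HPLC, with a stated time of 24 h (a lower number here means a stronger inhibitor, a higher number a weaker inhibitor), compound 3 gives 150 nM, the second highest of the three numbers: compound 1 sits higher and compound 2 lower, and both gaps lie beyond the usual scatter.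

Compound 4, `Cc1ccncc1N(C)C(=O)c1ccc(-c2ccc(OS(N)(=O)=O)cc2)o1`, has not been measured. It differs from compound 3 in one place: 4-methylpyridin-3-yl in place of 2-fluoro-6-methylphenyl on an amide-type nitrogen. Among the measured compounds shown here, no measured pair shows this kind of swap, so no step can be read directly from the data.

With no guide from a measured pair, a small step toward a higher number, probably not beyond the scatter, is expected, a 1.7-fold higher number from compound 3 to compound 4 (0.22 log units; within the scatter). Compound 4 is therefore estimated at 250 nM in this assay, within a range from 80 nM to 800 nM.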

Compound 4, half-maximal inhibitory concentration: 820 nM
Compound 4: the middle estimate sits 3.3-fold (0.52 log units) below what was measured, outside the stated range (above it).
By their numbers in this assay, from the lowest: compound 2; then compound 3; then compounds 1 and 4 (each within the scatter of the next).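

The ring on this amide-type nitrogen matters: in this assay, 4-methylpyridin-3-yl in place of 2-fluoro-6-methylphenyl gives a 5.5-fold higher number from compound 3 to compound 4 (0.74 log units; beyond the scatter). This single swap removes the fluorine and puts a ring nitrogen into the ring, and the step cannot show which of these changes accounts for the higher number. No measurement shown bears on the reason for the step. Still open, on these data alone, is whether an amine or a methoxy group on the pyridine ring would bring the number back down.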